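This account rests on a few compounds, and the source may have more. Where it says the series, first, only, none or still open, it means among the compounds named here.

In a functional assay on RXF 393 cells (Homo sapiens) for inhibition, read by sulforhodamine B assay, with a stated time of 48 h, tested at 100 uM (on this read-out higher numbers stand for a weaker effect at the one concentration tested and lower numbers for a stronger effect), compound 3 `COc1cc(Cl)cc(-c2nn(-c3cccc(NC(=O)Nc4cc(C(F)(F)F)cc(C(F)(F)F)c4)c3)cc2-c2ccncc2)c1` gives -92%, the lowest of the three numbers; compound 1 `O=C(Nc1cccc(-n2cc(-c3ccncc3)c(-c3cc(O)cc(Cl)c3)n2)c1)Nc1ccc(Cl)c(C(F)(F)F)c1` gives -72% and compound 2 `O=C(Nc1cccc(-n2cc(-c3ccncc3)c(-c3cc(O)cc(Cl)c3)n2)c1)Nc1ccc(Cl)c(Cl)c1` gives -52%, both higher beyond the scatter. Compound 4 `COc1cc(Cl)cc(-c2nn(-c3cccc(NC(=O)Nc4cccc(C(F)(F)F)c4)c3)cc2-c2ccncc2)c1` differs from compound 3 by hydrogen in place of trifluoromethyl on an aromatic carbon. Within the data shown here, the one measured step that bears on this change is a number 20 percentage points higher from compound 1 to compound 2 (beyond the scatter), where a trifluoromethyl was likewise removed, although chloro rather than hydrogen took its place. A step of similar or somewhat larger size towards a weaker effect is therefore expected in this assay for compound 4. Compound 4 is accordingly estimated at -65%, with a range from -90% to -35%, which means an expected step of a number 27 percentage points higher from compound 3 to compound 4 (beyond the scatter).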

Compound 4, a percentage reported as activity, at one concentration (the size of the read-out at that concentration, not a potency): -80%
Beside the measured number, compound 4's estimate is 15 percentage points above it; low and high end bracket the measured number.
By their numbers in this assay, from the lowest: compound 3; then compounds 4 and 1 (each within the scatter of the next); then compound 2.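

In this assay, among these compounds, hydrogen in place of trifluoromethyl on this aromatic carbon gives a number 12 percentage points higher from compound 3 to compound 4 (beyond the scatter) and so shows, for the first time, what happens when no substituent at all remains at this place. The loss of this trifluoromethyl group is a modest change, and the effect stays strong without it. Nothing measured here explains the step.

The compounds shown leave open how an amine or a carboxylic acid on this same carbon would read. They also leave open whether removing the remaining trifluoromethyl group would change the read-out further.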